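A few compounds are considered here, and "the series" means these few. Any claim that something is new, unique, unknown or untested is made for them only; others in the source may bear on it.

Three compounds sharing one core have numbers in a functional assay on KB-VIN10 cells (Homo sapiens) for inhibition, with a stated time of 72 h; a lower number here means a stronger inhibitor, a higher number a weaker inhibitor. Compound 1 `COc1ccc(S(=O)(=O)N2CCc3cccc(-c4ccc(F)nc4)c32)cc1` gives 151 nM, compound 2 `COc1ccc(S(=O)(=O)N2CCc3cccc(-c4ccc(F)c(F)c4)c32)cc1` gives 46 nM, and compound 3 `COc1ccc(S(=O)(=O)N2CCc3cccc(-c4ccc(F)cc4)c32)cc1` gives 94.6 nM. Compound 1 therefore sits at the weaker end of this small set, level within the scatter with compound 3 and clearly weaker than compound 2.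

Compound 4 `COc1ccc(S(=O)(=O)N2CCc3cccc(-c4ccncc4)c32)cc1` keeps the core of compound 1 but carries pyridin-4-yl in place of 6-fluoropyridin-3-yl on an aromatic carbon. For the measured compounds named here, no measured step makes this exact change, so the evidence is indirect. Replacing the same group with 4-fluorophenyl gives a 1.6-fold lower number from compound 1 to compound 3 (0.20 log units; within the scatter), which is within the scatter. Replacing it with 3,4-difluorophenyl gives a 3.3-fold lower number from compound 1 to compound 2 (0.52 log units; beyond the scatter), a modest step and the largest seen here. Hydrogen in place of fluoro on the phenyl ring gives a 2.1-fold higher number from compound 2 to compound 3 (0.31 log units; beyond the scatter), also modest, so losing a fluoro has mattered once in this set, though on a different ring.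

Swaps at this site have so far moved the number only modestly, so the expected step in this assay is small and not beyond the scatter, a 1.8-fold lower number from compound 1 to compound 4 (0.25 log units; within the scatter), leaning lower as both swaps away from compound 1 did. For compound 4 the estimated value is 85 nM, with an expected range from 25 nM to 280 nM.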

Compound 4, half-maximal inhibitory concentration: 106 nM
Estimate against measurement, compound 4: 1.2-fold (0.10 log units) below; the measured number falls inside the stated range.
By their numbers in this assay, from the lowest: compound 2; then compounds 3, 4 and 1 (each within the scatter of the next).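

In this assay, exchanging 6-fluoropyridin-3-yl for pyridin-4-yl moves the nitrogen and removes the fluorine, yet the step stays small (a 1.4-fold lower number from compound 1 to compound 4 (0.15 log units; within the scatter)), and pyridin-4-yl also matches 4-fluorophenyl (a 1.1-fold higher number from compound 3 to compound 4 (0.05 log units; within the scatter)). Compound 4 thus shows that a ring carrying no fluorine can sit level with both compound 1 and compound 3, so fluorine is not required at this site for a number in this range, although the step from compound 2 to compound 3 had hinted that losing a fluoro could matter. For the compounds shown here, compound 2 remains the only compound that stands apart, now also from the new pyridine (a 2.3-fold higher number from compound 2 to compound 4 (0.36 log units; beyond the scatter)), and no measurement of any other property is available to explain these numbers.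

Every group shown here is a six-membered aromatic ring, so the compounds leave open how a saturated amine such as morpholine, a five-membered ring such as thiazole, or a carboxylic acid on the ring would behave at this position. They also leave open whether the 3,4-difluorophenyl result depends on its fluorines alone, since plain phenyl and pyridin-3-yl without fluorine do not appear among them.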